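Aromatic Ethenyl Group Expected to Lower Cytotoxicity

A few compounds are considered here, and "the series" means these few. Any claim that something is new, unique, unknown or untested is made for them only; others in the source may bear on it.

Compound 1 `CCOCC(=O)OCCc1c(-c2ccccc2Cl)c2cc(Cl)ccc2[nH]c1=O` was tested in an ADME assay on HepG2 2.2.15 cells (Homo sapiens) for cytotoxicity (on this read-out lower numbers stand for higher toxicity in this test and higher numbers for lower toxicity in this test), and gives 130000 nM. Compound 2 `O=C(COc1ccccc1)OCCc1c(-c2ccccc2Cl)c2cc(Cl)ccc2[nH]c1=O` gives 81000 nM in this assay; the step of a 1.6-fold lower number from compound 1 to compound 2 (0.21 log units; within the scatter) means the two sit together, with compound 1 showing the higher of the two numbers. For compound 3 `O=C(/C=C/c1ccc(C(F)(F)F)cc1)OCCc1c(-c2ccccc2Cl)c2cc(Cl)ccc2[nH]c1=O` this assay reports only a limit, > 1400000 nM. The step of an at least 10-fold higher number from compound 1 to compound 3 (1.03 log units; beyond the scatter) rests on (the limit of > 1400000 nM in this assay, at which 1 of the 3 values shown sits). Compound 4 `O=C(/C=C/c1cccnc1)OCCc1c(-c2ccccc2Cl)c2cc(Cl)ccc2[nH]c1=O` differs from compound 1 by 2-(pyridin-3-yl)ethenyl in place of ethoxymethyl on a carbonyl carbon. This change resembles the step to compound 3, where the same ethoxymethyl gave way to an ethenyl carrying an aromatic ring, so a large rise in the number is expected: a 3.8-fold higher number from compound 1 to compound 4 (0.59 log units; beyond the scatter). Compound 4 is therefore estimated at 500000 nM, with a range from 150000 nM to 1500000 nM.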

Compound 4, half-maximal cytotoxic concentration: 39000 nM
Compound 4: the middle estimate sits 13-fold (1.11 log units) above what was measured, outside the stated range (below it).
By their numbers in this assay, from the lowest: compound 4; then compounds 2 and 1 (each within the scatter of the next). At a limit, above all of these: compound 3.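

An ethenyl carrying an aromatic ring does not by itself raise the number in this assay at this carbonyl carbon: 2-(pyridin-3-yl)ethenyl gives a 3.3-fold lower number from compound 1 to compound 4 (0.52 log units; beyond the scatter), and also a 2.1-fold lower number from compound 2 to compound 4 (0.32 log units; beyond the scatter). The group on the ethenyl matters, since pyridin-3-yl in place of 4-(trifluoromethyl)phenyl gives an at least 35-fold lower number from compound 3 to compound 4 (1.55 log units; beyond the scatter). The size of that step is open-ended, as the value for compound 3 is a limit: the limit of > 1400000 nM in this assay, at which 1 of the 4 values shown sits.

Still open, as far as these compounds go, is whether the ring nitrogen or the trifluoromethyl group accounts for this gap. A plain 2-phenylethenyl at this carbonyl carbon would help separate the two.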